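The compounds below may be only part of what the source reports. "The series", "measured", "known", "first", "only" and "open" are said of these compounds alone.

Compound 1 `CC(O)C1=CC(=O)c2ccccc2C1=O` and compound 2 `O=C1C=C(C(O)c2ccc(F)cc2)C(=O)c2ccccc21` are the measured pair. In a functional assay on WHCO1 cells (Homo sapiens) for cytotoxicity, read by MTT assay, with a stated time of 24 h (on this read-out lower numbers stand for stronger inhibition and higher numbers for weaker inhibition), compound 1 gives 6400 nM and compound 2 gives 5100 nM; the pair sit within the scatter of each other, as a 1.3-fold lower number from compound 1 to compound 2 (0.10 log units; within the scatter) shows. Compound 3 `O=C1C=C(C(O)c2ccoc2)C(=O)c2ccccc21` carries furan-3-yl in place of 4-fluorophenyl on a saturated chain carbon bound to a double-bonded ring carbon and an oxygen on a saturated carbon. Among the compounds with values here, the only step at this position, a 1.3-fold lower number from compound 1 to compound 2 (0.10 log units; within the scatter), lies within the scatter, so compound 3 is expected to stay close to compound 2, with a 1.1-fold higher number from compound 2 to compound 3 (0.03 log units; within the scatter) as the estimated step. Compound 3 is therefore estimated at 5500 nM, with a range from 2500 nM to 12000 nM.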

Compound 3, half-maximal inhibitory concentration: 10900 nM
Estimate against measurement, compound 3: 2.0-fold (0.30 log units) below, and the stated range covers the measured number.
By their numbers in this assay, from the lowest: compounds 2, 1 and 3 (each within the scatter of the next, the first and the last beyond it).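

In this assay, within the data shown here, this position does respond to which ring it carries: furan-3-yl in place of 4-fluorophenyl gives a 2.1-fold higher number from compound 2 to compound 3 (0.33 log units; beyond the scatter), the first step beyond the scatter, though a modest one. Against the methyl of compound 1, furan-3-yl gives a 1.7-fold higher number from compound 1 to compound 3 (0.23 log units; within the scatter), so only the two rings are told apart and methyl stays within the scatter of both. Nothing measured here explains the difference between the rings. Open, from the compounds shown here alone, is how an unsubstituted phenyl, an amine or a longer chain would behave at this position.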